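A few compounds are considered here, and "the series" means these few. Any claim that something is new, unique, unknown or untested is made for them only; others in the source may bear on it.

Measured in an ADME assay on HEK-293T cells (Homo sapiens) for cytotoxicity, read by CCK-8 assay, with a stated time of 24 h; a lower number here means that less compound is tolerated, a higher number that more compound is tolerated:
- Compound 1 `O=C(CSc1c[nH]c2ccccc12)NCc1ccc(C(F)(F)F)cc1`: > 100000 nM (a limit)
- Compound 2 `Cn1cc(SCC(=O)NCc2ccc(Cl)c(Cl)c2)c2ccccc21`: > 100000 nM (a limit)
- Compound 3 `COc1ccccc1CNC(=O)CSc1c[nH]c2c(-c3ccccc3)cccc12`: 95500 nM

Compound 2 reads > 100000 nM, which is a limit of the assay and not a number. Compound 2 stands with compound 1 at the limit of > 100000 nM in this assay, at which 2 of the 3 values shown sit. Compound 3 is the only one of the three with a number.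

Compound 4 `COc1ccccc1CNC(=O)CSc1cn(C)c2ccccc12` is the next to be read in this assay. The change is 2-methoxyphenyl in place of 3,4-dichlorophenyl on a saturated chain carbon bound to an amide-type nitrogen. Compound 3 also carries 2-methoxyphenyl, on a different core, and gives 95500 nM, so no step beyond the scatter is expected. The expected step is a number no higher from compound 2 to compound 4 (the limit leaves the size open). For compound 4 the estimate is 100000 nM, with an expected range of 50000 nM to 200000 nM.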

Compound 4, half-maximal cytotoxic concentration: > 100000 nM
Compound 4 ended at the assay's limit; the forecaster's own chance of this, stated with the estimate: 75%; the middle value lies on the limit itself.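

Among these compounds, compound 2 and compound 4 both give limits and not numbers, so no step between them can be read: the limit of > 100000 nM in this assay, at which 3 of the 4 values shown sit. The compounds shown leave open whether 2-methoxyphenyl and 3,4-dichlorophenyl differ at all in tolerated concentration on the shared core.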